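Shifting One Fluorine: From Compound 2 to Compound 3

The source may report more compounds than this note shows. Statements on the series, on what has been measured and on what is new or still open speak of the compounds shown alone.

Compound 2 `CC[C@H](C)[C@H](N)CN(C(=O)[C@@H]1C[C@H]1c1ccc(F)c(F)c1)c1ccc(-c2ccccc2)cc1` gives 720 nM in a functional assay for agonist activity at G protein-coupled receptor 88 (Homo sapiens), read by HTRF and cAMP accumulation (a higher number here means that more compound is needed for the effect, a lower number that less compound is needed), the highest of the two numbers seen so far, though its neighbour compound 1 `CC[C@H](C)[C@H](N)CN(C(=O)[C@@H]1C[C@H]1c1ccc(F)cc1)c1ccc(-c2ccccc2)cc1` gives 600 nM and the step of a 1.2-fold higher number from compound 1 to compound 2 (0.08 log units; within the scatter) lies within the scatter. Compound 3 `CC[C@H](C)[C@H](N)CN(C(=O)[C@@H]1C[C@H]1c1ccc(F)cc1F)c1ccc(-c2ccccc2)cc1` differs from compound 2 by 2,4-difluorophenyl in place of 3,4-difluorophenyl on a saturated ring carbon. Among the compounds with values here, no measured step moves a fluorine from one ring position to another, and the single step measured, adding a fluorine to that same ring, hardly changed the number. Compound 3 is therefore expected to give about 700 nM, within 300 nM to 1700 nM, an expected step of a 1.0-fold lower number from compound 2 to compound 3 (0.01 log units; within the scatter) that should stay within the scatter.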

Compound 3, half-maximal effective concentration: 1300 nM
The estimate for compound 3 lay 1.9-fold (0.27 log units) below the measured number; the range from low to high includes it.
By their numbers in this assay, from the lowest: compounds 1, 2 and 3 (each within the scatter of the next, the first and the last beyond it).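

Moving a fluorine around the ring, with 2,4-difluorophenyl in place of 3,4-difluorophenyl, gives a 1.8-fold higher number from compound 2 to compound 3 (0.26 log units; within the scatter) in this assay and so stays inside the noise of the measurement. Adding a fluorine to the ring can nevertheless matter: a 2.2-fold higher number from compound 1 to compound 3 (0.34 log units; beyond the scatter) is a modest step, but the first here to pass beyond the scatter, which the added fluorine of compound 2 did not do. No other data shown bear on this result. On these data alone, whether a chloro or methoxy group on this ring would give a similar number stays open.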